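Cyclohexyl for phenyl on a tetrahydroisoquinoline-type core

The source may hold more compounds than are shown below. What is called first, only, known or untested is meant among the compounds shown, and "the series" means these compounds.

Compound 1 `C=CCN1CCc2ccccc2C1c1ccccc1`: 1300 nM
Compound 2 `Fc1ccc(C2NCCc3ccccc32)cc1`: 1800 nM

Among the compounds with values here, the series so far consists of two measured compounds tested in an assay on isolated protein for binding affinity to Sigma non-opioid intracellular receptor 1 (Rattus norvegicus); on this read-out lower numbers stand for stronger inhibition and higher numbers for weaker inhibition. Compound 1 gives 1300 nM in this assay, and compound 2 gives 1800 nM. Compound 1 has the lowest of the two numbers, but its nearest neighbour, compound 2, lies within the scatter, so the two cannot be told apart on these data.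

Compound 3 `C=CCN1CCc2ccccc2C1C1CCCCC1` has not yet been measured. It differs from compound 1 in one place: cyclohexyl in place of phenyl on a saturated ring carbon. Within the data shown here, no measured pair shows what this change does, so the size and direction of the step from compound 1 to compound 3 in this assay rest on expectation alone. A small shift toward a lower number is expected, not clearly beyond the scatter, so that the estimated step of a 1.4-fold lower number from compound 1 to compound 3 (0.16 log units; within the scatter) stays modest. For compound 3 the value in this assay is estimated at 900 nM, with a range from 250 nM to 3500 nM.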

Compound 3, half-maximal inhibitory concentration: 3100 nM
The estimate for compound 3 lay 3.4-fold (0.54 log units) below the measured number; the measured number falls inside the stated range.
By their numbers in this assay, from the lowest: compounds 1, 2 and 3 (each within the scatter of the next, the first and the last beyond it).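

Cyclohexyl in place of phenyl on a saturated ring carbon, next to the ring nitrogen, gives a 2.4-fold higher number from compound 1 to compound 3 (0.38 log units; beyond the scatter) in this assay, the first step read at this position. The position therefore does not treat these two groups alike, even though they match in their six carbon heavy atoms, their hydrogen-bond donor and acceptor counts and their lack of net charge; of the features counted, the clear difference is that the phenyl ring is aromatic and the cyclohexyl ring is not. Nothing measured here accounts for the step, so this single pair records its size and direction without explaining it.

The compounds shown leave open how other groups would read on this carbon, such as a pyridyl ring, a cyclopentyl ring or a plain methyl group, so it remains unknown whether phenyl is a favourable choice here or simply the better of these two. They also leave open whether the same change gives a similar step without the allyl group on the ring nitrogen, as in the free ring nitrogen of compound 2.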